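From a hydroxy group to a cyano group

The source may hold more compounds than are shown below. What is called first, only, known or untested is meant among the compounds shown, and "the series" means these compounds.

Compound 1 `COc1ccc(S(=O)(=O)N2CCc3cccc(-c4ccc(F)nc4)c32)cc1` gives 151 nM 
Compound 2 `COc1ccc(S(=O)(=O)N2CCc3cccc(-c4ccc(O)cc4)c32)cc1` gives 123 nM 

Both numbers come from a functional assay on KB-VIN10 cells (Homo sapiens) for inhibition, with a stated time of 72 h (a lower number here means a stronger inhibitor, a higher number a weaker inhibitor), and they lie within the usual scatter of each other, so compound 2 stands level with compound 1 on the data so far. The next structure is compound 3 `COc1ccc(S(=O)(=O)N2CCc3cccc(-c4ccc(C#N)cc4)c32)cc1` which keeps the shared core and alters a single group. Its difference from compound 2 is cyano in place of hydroxy on an aromatic carbon and in words this is cyano in place of hydroxy on an aromatic carbon, para to a large group.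

Within the data shown here, only one measured step offers guidance: a 1.2-fold lower number from compound 1 to compound 2 (0.09 log units; within the scatter) and this swap of a whole aromatic group stayed within the scatter. Among the measured compounds shown here, no measured compound carries a cyano group, so this small step is thin evidence. On that basis, no change beyond the scatter is expected, and no firm direction can be given. The estimated move is a 1.1-fold higher number from compound 2 to compound 3 (0.06 log units; within the scatter) in this assay and it remains an expectation. Compound 3 is expected to read 140 nM with an estimated range of 50 nM to 400 nM until it is measured.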

Compound 3, half-maximal inhibitory concentration: 29.2 nM
Compound 3: middle estimate off by 4.8-fold (0.68 log units), on the high side; measured number outside the range, below it.
By their numbers in this assay, from the lowest: compound 3; then compounds 2 and 1 (each within the scatter of the next).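

In this assay the group at this position turns out to matter: replacing the hydroxy group with a cyano group, para to a large group, gives a 4.2-fold lower number from compound 2 to compound 3 (0.62 log units; beyond the scatter) and lies beyond the scatter. Among these compounds, the earlier compounds could not show this, as their only step stayed within the scatter even though a whole aromatic group was exchanged. The 4-cyanophenyl group also stands clear of the 6-fluoropyridin-3-yl group, with a 5.2-fold lower number from compound 1 to compound 3 (0.71 log units; beyond the scatter) as the step, so compound 3 has the lowest number of the three and its steps to both others are beyond the scatter. Nothing available explains the gain, so these steps record an outcome and not its cause.

The compounds shown leave open whether the low number belongs to cyano specifically or would also appear with other groups in the same place, such as an amine, an amide or a carboxylic acid. They also leave open how much the result depends on the cyano group staying para to the large group, and whether the same exchange would give a step of similar size on a different core.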